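A few compounds are considered here, and "the series" means these few. Any claim that something is new, unique, unknown or untested is made for them only; others in the source may bear on it.

Of the compounds shown here, three built on one shared core have been measured in an ADME assay on HepG2 2.2.15 cells (Homo sapiens) for cytotoxicity; on this read-out higher numbers stand for lower toxicity in this test and lower numbers for higher toxicity in this test. Compound 3 `CC(=O)NCC(=O)OCCc1c(-c2ccccc2Cl)c2cc(Cl)ccc2[nH]c1=O` gives 110000 nM, the second highest of the three numbers. Its nearest neighbour is compound 2 `CCOCC(=O)OCCc1c(-c2ccccc2Cl)c2cc(Cl)ccc2[nH]c1=O`, which gives 130000 nM in this assay, and the furthest is compound 1 `CCCCCCCC(=O)OCCc1c(-c2ccccc2Cl)c2cc(Cl)ccc2[nH]c1=O`, which gives 78000 nM. None of the three separates from the others: a 1.7-fold higher number from compound 1 to compound 2 (0.22 log units; within the scatter), a 1.4-fold higher number from compound 1 to compound 3 (0.15 log units; within the scatter) and a 1.2-fold lower number from compound 2 to compound 3 (0.07 log units; within the scatter) all fall within the scatter.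

Compound 4 `O=C(CCOc1ccccc1)OCCc1c(-c2ccccc2Cl)c2cc(Cl)ccc2[nH]c1=O` differs from compound 3 in one place: phenoxymethyl in place of acetamido on a saturated chain carbon bound to a carbonyl carbon. All three measured steps vary the group on a saturated chain carbon bound to a carbonyl carbon, and none of them moved the read-out beyond the scatter. For the measured compounds named here, no measured step brings a six-membered aromatic ring of carbon only into that place, so the change to compound 4 reaches somewhat past the variation covered so far. On the evidence at hand, the number for compound 4 is expected to stay close to that of compound 3, with a 1.1-fold lower number from compound 3 to compound 4 (0.04 log units; within the scatter) expected to lie within the scatter. Compound 4 is therefore estimated at 100000 nM, within a range from 40000 nM to 250000 nM.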

Compound 4, half-maximal cytotoxic concentration: 46000 nM
Beside the measured number, compound 4's estimate is 2.2-fold (0.34 log units) above it; the range from low to high includes it.
By their numbers in this assay, from the lowest: compounds 4, 1, 3 and 2 (each within the scatter of the next, the first and the last beyond it).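

In this assay, for the compounds shown here, phenoxymethyl brings the first six-membered aromatic ring of carbon only to the saturated chain carbon bound to a carbonyl carbon, and it gives the first steps at this place to pass the scatter, with a 2.4-fold lower number from compound 3 to compound 4 (0.38 log units; beyond the scatter) and a 2.8-fold lower number from compound 2 to compound 4 (0.45 log units; beyond the scatter) both modest. The read-out at this place therefore does respond to the group, though not against every partner, since a 1.7-fold lower number from compound 1 to compound 4 (0.23 log units; within the scatter) leaves those two compounds unseparated, so the hexyl compound goes against any simple split between the aromatic group and the others. Nothing available here accounts for this shift. From the compounds shown here alone, whether it follows the aromatic ring, the ether oxygen or the chain length stays open. A plain phenyl, a pyridine ring or an amine at this place would help to separate these readings.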